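This account rests on a few compounds, and the source may have more. Where it says the series, first, only, none or still open, it means among the compounds named here.

Measured compounds:
compound 1 `c1ccc(NCc2ccc(CNc3ncccn3)cc2)cc1` — 100%
compound 2 `Clc1cccc(NCc2ccc(CNc3ncccn3)cc2)n1` — 100%

In a functional assay on MDA-MB-231 cells for antagonist activity at C-X-C chemokine receptor type 4 (Homo sapiens), tested at 100 nM (a lower number here means a weaker effect, a higher number a stronger effect of the compound at the concentration tested), compound 1 gives 100% and stands level with compound 2, the step of no change at the digits printed from compound 1 to compound 2 (within the scatter) lying within the scatter. Compound 3 `c1cnc(NCc2ccc(CNc3cccc(N4CCCC4)c3)cc2)nc1` has not been measured; it differs from compound 1 by pyrrolidin-1-yl in place of hydrogen on an aromatic carbon. Going by the values given here, no measured step puts a pyrrolidin-1-yl onto this ring; the one step recorded, from compound 1 to compound 2, alters a different part of the molecule and shows no change. The step from compound 1 to compound 3 is therefore expected to be no larger than the scatter, a number 2 percentage points lower from compound 1 to compound 3 (within the scatter). Compound 3 is estimated at 98%, between 85% and 100%.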

Compound 3, a percentage reported as inhibition, at one concentration (the size of the read-out at that concentration, not a potency): 78%
Compound 3: the middle estimate sits 20 percentage points above what was measured; measured number below the stated range.
By their numbers in this assay, from the lowest: compound 3; then compounds 1 and 2 (each within the scatter of the next).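

In this assay, going by these compounds alone, the step of a number 22 percentage points lower from compound 1 to compound 3 (beyond the scatter) is the first change here to go beyond the scatter, whereas the earlier swap of phenyl for 6-chloropyridin-2-yl left the read-out unmoved. It shows that this aromatic carbon, meta to a large group, does not tolerate pyrrolidin-1-yl without loss, although compound 3 keeps a substantial 78%. Nothing available explains this loss.

Going by these compounds, it remains open whether the loss belongs to the ring itself or to any group at this carbon. A dimethylamino group, a morpholin-4-yl ring or a methoxy group there could separate these readings.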